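Notes on a terminal aryl swap, cytotoxicity read-out

This account rests on a few compounds, and the source may have more. Where it says the series, first, only, none or still open, it means among the compounds named here.

Compound 1 `CC(C)COc1cccc(-c2ccc(C(=O)N(Cc3cccc(OCCCCCC(=O)O)c3)C(C)C)cc2)c1` gives in an ADME assay on BJ cells (Homo sapiens) for cytotoxicity, read by CellTiter-Glo and resazurin assay, with a stated time of 72 h (on this read-out lower numbers stand for an effect already at smaller amounts and higher numbers for an effect only at larger amounts of compound), only a limit, > 26000 nM.
Compound 2 `CC(C)N(Cc1cccc(OCCCCCC(=O)O)c1)C(=O)c1ccc(-c2cccc(OCc3ccccc3)c2)cc1` gives in this assay only a limit, > 26000 nM.
Compound 3 `CC(C)N(Cc1cccc(OCCCCCC(=O)O)c1)C(=O)c1ccc(-c2ccc3[nH]ccc3c2)cc1` gives in this assay only a limit, > 26000 nM.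

Going by the values given here, compound 1 stands at the limit of this assay with no number of its own; the same holds for every value so far, as the limit of > 26000 nM in this assay, at which 3 of the 3 values shown sit, shows. The two measured steps that leave compound 1, a step that the two limits leave unreadable from compound 1 to compound 2 and a step that the two limits leave unreadable from compound 1 to compound 3, run from one limit to another and therefore carry no readable size in either direction.

Compound 4 `CC(C)N(Cc1cccc(OCCCCCC(=O)O)c1)C(=O)c1ccc(-c2ccc3c(c2)OCCO3)cc1` is the next in line. Change: 2,3-dihydro-1,4-benzodioxin-6-yl in place of 3-(isobutoxy)phenyl on an aromatic carbon. Among the compounds with values here, no measured step gives a readable size for any exchange at this aromatic carbon, so nothing here points to a step beyond the scatter, and nothing points to a numerical value emerging in this assay either. Compound 4 is therefore expected to stay at the limit, with a step that the limit leaves unreadable from compound 1 to compound 4 expected to be no change that could be read. Compound 4 is estimated at 35000 nM, with a range from 20000 nM to 80000 nM.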

Compound 4, half-maximal effective concentration: > 21900 nM
Compound 4: only a limit was reported; the forecaster's own chance of this, stated with the estimate: 85%; the middle value is on the limit's open side.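

Compound 4 gives only a limit, so neither its step from compound 1 nor its step from compound 3 can be read in this assay as measured. The compounds shown leave open whether any group at this aromatic carbon yields a numerical value in this assay at all.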